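Removing one methoxy from the aryl ring of the series

This account rests on a few compounds, and the source may have more. Where it says the series, first, only, none or still open, it means among the compounds named here.

Working notes on three measured compounds and one still open, all on a shared core. Compound 1 `COc1cc(-c2cc(/C=C/C(=O)c3ccc(N)cc3)[nH]n2)cc(OC)c1OC` is the reference point; in a functional assay on LOX IMVI cells (Homo sapiens) for cytotoxicity, read by sulforhodamine B assay, with a stated time of 48 h, tested at 10 uM (on this read-out higher numbers stand for a weaker effect at the one concentration tested and lower numbers for a stronger effect), compound 1 gives -78%. Compound 2 `COc1ccc(-c2cc(/C=C/C(=O)c3ccc(N)cc3)[nH]n2)cc1OC` differs from compound 1 in one place only, namely (hydrogen in place of methoxy on an aromatic carbon), and in this assay compound 2 gives -66%. The resulting step of a number 12 percentage points higher from compound 1 to compound 2 (beyond the scatter) is a modest weakening that still lies beyond the scatter. Compound 3 `COc1cc(C(=O)/C=C/c2cc(-c3cc(OC)c(OC)c(OC)c3)n[nH]2)cc(OC)c1OC` holds the same parts in a different arrangement; the difference between the core of compound 1 and the core of compound 3 is not broken down here. In this assay compound 3 gives -95%, the strongest read-out of the three, with its gaps to compound 1 and to compound 2 both beyond the scatter.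

Compound 4 `COc1ccc(-c2cc(/C=C/C(=O)c3cc(OC)c(OC)c(OC)c3)[nH]n2)cc1OC` has not yet been measured in this assay. It is derived from compound 3 by hydrogen in place of methoxy on an aromatic carbon, which is the same change as from compound 1 to compound 2, in surroundings described in identical terms. The working expectation is that the step carries over in size, so a step of a number 12 percentage points higher from compound 3 to compound 4 (beyond the scatter) is estimated. For the measured compounds named here, that expectation rests on compound 1 and compound 2, because a number 12 percentage points higher from compound 1 to compound 2 (beyond the scatter) is the only instance of this change measured so far, and on compound 3 as the starting value. For compound 4 the estimate in this assay is -83%, with a plausible range from -95% to -68%.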

Compound 4, a percentage reported as activity, at one concentration (the size of the read-out at that concentration, not a potency): -91%
Compound 4: the middle estimate sits 8 percentage points above what was measured; the range from low to high includes it.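

On the core of compound 3, the change of hydrogen in place of methoxy gives in this assay a step of a number 4 percentage points higher from compound 3 to compound 4 (within the scatter), so on this core the loss of the methoxy leaves no effect that can be told apart from the usual spread of repeat measurements. Set beside the only other instance of the change, the step on the core of compound 1 does not differ from it by more than repeat measurements allow: the same change on two cores in this assay, a number 12 percentage points higher (beyond the scatter) from compound 1 to compound 2 and a number 4 percentage points higher (within the scatter) from compound 3 to compound 4, 8 percentage points apart, within the scatter of two such steps The two cores are therefore compatible with one modest step carried from one to the other, but two pairs do not establish a rule, and they show neither that the step has a fixed size nor that the core leaves it untouched.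

Still open, going by these compounds, is whether a hydroxyl group or a chlorine atom in that place would track hydrogen on both cores, and whether an acetamide in place of the amine of compound 1 and compound 2 would keep the read-out. Every value here also comes from a single concentration, which leaves the potency of all four compounds open.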